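The source may hold more compounds than are shown below. What is called first, only, known or untested is meant among the compounds shown, and "the series" means these compounds.

Measured compounds:
compound 1 `COc1cc(-c2cc(/C=C/C(=O)c3ccc(N)cc3)[nH]n2)cc(OC)c1OC`, 93%
compound 2 `COc1ccc(C(=O)/C=C/c2cc(-c3cc(OC)c(OC)c(OC)c3)n[nH]2)cc1OC`, 90%

Both compounds share the same core and differ only in the aryl group attached to the carbonyl carbon. In a functional assay on BT-549 cells (Homo sapiens) for cytotoxicity, read by sulforhodamine B assay, with a stated time of 48 h, tested at 0.1 uM (a lower number here means a stronger effect, a higher number a weaker effect of the compound at the concentration tested), compound 1 gives 93%, and compound 2 gives 90%. The step of a number 3 percentage points lower from compound 1 to compound 2 (within the scatter) was within the scatter, so compound 2 stands lowest of the two numbers without being separable from compound 1.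

Compound 3 `COc1ccc(C(=O)/C=C/c2cc(-c3cc(OC)c(OC)c(OC)c3)n[nH]2)cc1` is not yet measured. It differs from compound 2 by hydrogen in place of methoxy on an aromatic carbon, which is a change at the dimethoxyphenyl group on the carbonyl carbon. Going by the values given here, the only measured step concerns an exchange of that whole aryl group, not a single methoxy, so it bears on this change only loosely; it showed no effect beyond the scatter. The expected step of no change at the digits printed from compound 2 to compound 3 (within the scatter) in this assay is therefore none beyond the scatter. Compound 3 is estimated at 90%, ranging from 78% to 100%.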

Compound 3, a percentage reported as activity, at one concentration (the size of the read-out at that concentration, not a potency): 97%
Compound 3: the middle estimate sits 7 percentage points below what was measured, and the stated range covers the measured number.
By their numbers in this assay, from the lowest: compounds 2, 1 and 3 (each within the scatter of the next).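

Compound 3 carries 4-methoxyphenyl where compound 2 carries 3,4-dimethoxyphenyl. In this assay the step is a number 7 percentage points higher from compound 2 to compound 3 (within the scatter), so this exchange leaves no difference that can be separated from the scatter at the single concentration tested. Methoxy in place of amino on an aromatic carbon reads the same way, with a number 4 percentage points higher from compound 1 to compound 3 (within the scatter), so the three aryl groups on the carbonyl carbon stand within the scatter of one another. No evidence accompanies these values that would bear on this result.

The compounds shown leave open whether a hydroxyl group, a fluorine atom or a longer ethoxy chain on this aromatic carbon would move the read-out beyond the scatter. They also leave open whether any of these exchanges would separate at another concentration.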